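The source may report more compounds than this note shows. Statements on the series, on what has been measured and on what is new or still open speak of the compounds shown alone.

Compound 3 `Cc1ccc2ncc(S(=O)(=O)c3ccc(F)cc3)c(N3CCC(C)CC3)c2c1` stands highest of the three compounds measured in an assay on isolated protein for displacement of a labelled ligand from metabotropic glutamate receptor 5 (Homo sapiens), with a stated time of 60 min, tested at 1 uM; a lower number here means less inhibition, a higher number more inhibition at the concentration tested (going by the name of the read-out): compound 3 gives 90%. Compound 2 `CC1CCN(c2c(S(=O)(=O)c3cc(Cl)cc(Cl)c3)cnc3ccc(F)cc23)CC1` is nearest, and compound 2 gives 69%. Compound 1 `COc1ccc(S(=O)(=O)c2cnc3ccc(C)cc3c2N2CCC(C)CC2)cc1` is furthest, and compound 1 gives 62%.

The one measured step that joins two of these compounds in a single change is a number 28 percentage points higher from compound 1 to compound 3 (beyond the scatter); that change sits on the sulfonyl-bearing aryl ring, not on the shared core.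

Compound 4 `CC1CCN(c2c(S(=O)(=O)c3ccc(F)cc3)cnc3ccc(F)cc23)CC1` has not yet been measured. It differs from compound 3 in one place: fluoro in place of methyl on an aromatic carbon. Going by the values given here, no measured step changes this position alone. Among the compounds with values here, compound 2 also carries fluoro at this place on the core, but compound 2 differs from compound 3 in its sulfonyl-bearing aryl ring as well, so its value cannot be tied to the core change by itself; the two values show only that compound 2 sits lower than compound 3.

Within the data shown here, with no direct precedent, a small downward drift or no step beyond the scatter is expected for compound 4: the step from compound 3 is estimated as a number 10 percentage points lower from compound 3 to compound 4 (within the scatter). Compound 4 is therefore expected to give about 80% in this assay, within a range of 60% to 95%.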

Compound 4, a percentage reported as inhibition, at one concentration (the size of the read-out at that concentration, not a potency): 87%
Beside the measured number, compound 4's estimate is 7 percentage points below it; the measured number falls inside the stated range.
By their numbers in this assay, from the lowest: compounds 1 and 2 (each within the scatter of the next); then compounds 4 and 3 (each within the scatter of the next).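

In this assay, fluoro in place of methyl on this aromatic carbon of the shared core gives a number 3 percentage points lower from compound 3 to compound 4 (within the scatter), so the read-out does not separate the two groups at this position. Going by these compounds alone, with fluoro held constant on the core, 4-fluorophenyl in place of 3,5-dichlorophenyl on the sulfonyl sulfur gives a number 18 percentage points higher from compound 2 to compound 4 (beyond the scatter), which for the first time isolates a change in the sulfonyl-bearing aryl ring on this core and ties the gap between these two compounds to that ring alone. Nothing available here explains the size of either step.

The compounds shown leave open whether this position would accept groups other than methyl and fluoro, such as a nitrile, an amine or a longer chain like propyl, or whether the read-out would then fall. Each number is also the size of the read-out at one concentration and not a potency, so compound 3 and compound 4 might still separate in a full concentration series.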